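The source may hold more compounds than are shown below. What is called first, only, known or untested is meant among the compounds shown, and "the series" means these compounds.

Of the compounds shown here, three sharing one core have been measured. Compound 1 `Nc1cc(N)c2nc(-c3ccccc3)c(NCc3ccc(Cl)c(Cl)c3)nc2c1` gives 40700 nM in a functional assay on OVCAR-5 cells (Homo sapiens) for inhibition, read by sulforhodamine B assay, with a stated time of 48 h (a lower number here means a stronger inhibitor of growth, a higher number a weaker inhibitor of growth), compound 2 `COc1ccc(CNc2nc3cc(N)cc(N)c3nc2-c2ccccc2)cc1OC` gives 41700 nM, and compound 3 `Nc1cc(N)c2nc(-c3ccccc3)c(NCc3ccc(F)cc3)nc2c1` gives 7590 nM. Compound 3 thus shows the lowest number of the three: the step from compound 1 to compound 3 is a 5.4-fold lower number from compound 1 to compound 3 (0.73 log units; beyond the scatter), and the step from compound 2 to compound 3 is a 5.5-fold lower number from compound 2 to compound 3 (0.74 log units; beyond the scatter), while compound 1 and compound 2 stand within the scatter of each other, as a 1.0-fold higher number from compound 1 to compound 2 (0.01 log units; within the scatter) shows.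

Compound 4 `COc1ccc(CNc2nc3cc(N)cc(N)c3nc2-c2ccccc2)cc1` has not yet been measured. It differs from compound 3 by methoxy in place of fluoro on an aromatic carbon. Neither measured step tests exactly this change; the closest point of reference is compound 2, whose 3,4-dimethoxyphenyl gave a number beyond the scatter higher than the 4-fluorophenyl of compound 3. Going by the values given here, since compound 2 gives 41700 nM, a rise from compound 3 is expected, though smaller than that full gap: the single methoxy of compound 4 is not the same as the pair in compound 2. The expected step is a 2.1-fold higher number from compound 3 to compound 4 (0.32 log units; beyond the scatter), and compound 4 is estimated at 16000 nM, between 5000 nM and 45000 nM.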

Compound 4, concentration for total growth inhibition: 45700 nM
Compound 4: the middle estimate sits 2.9-fold (0.46 log units) below what was measured, and the stated range ends below it.
By their numbers in this assay, from the lowest: compound 3; then compounds 1, 2 and 4 (each within the scatter of the next).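

In this assay, a single methoxy in place of fluoro on the aromatic carbon para to a large group is enough to give the whole rise (a 6.0-fold higher number from compound 3 to compound 4 (0.78 log units; beyond the scatter)). The second methoxy of compound 2 adds nothing that can be told apart, since hydrogen in its place stays within the scatter (a 1.1-fold higher number from compound 2 to compound 4 (0.04 log units; within the scatter)). The 4-methoxyphenyl group also stands level with the 3,4-dichlorophenyl group (a 1.1-fold higher number from compound 1 to compound 4 (0.05 log units; within the scatter)), so among these four compounds only the 4-fluorophenyl group of compound 3 stands apart.

Nothing shown here explains why fluoro differs from methoxy at this position. On these data alone, it also remains open whether fluoro is special or whether another small group there, such as a hydroxyl, an amine or a lone chlorine, would give a similar number.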